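Chloro for hydroxy on the aryl of the thiosemicarbazone

The source may report more compounds than this note shows. Statements on the series, on what has been measured and on what is new or still open speak of the compounds shown alone.

The series is measured in a functional assay on NCI-H460 cells (Homo sapiens) for inhibition, read by sulforhodamine B assay, with a stated time of 48 h; a lower number here means a stronger inhibitor of growth, a higher number a weaker inhibitor of growth. Compound 1 `CC1=CC[C@H](C(C)(C)NC(=S)NN)CC1`, the bare hydrazide, gives 42000 nM. Compound 2 `CC1=CC[C@H](C(C)(C)NC(=S)N/N=C/c2ccc(O)cc2)CC1` gives only a limit, > 100000 nM, so its number is not known; it stands at the limit of > 100000 nM in this assay, at which 1 of the 3 values shown sits. Among the measured compounds shown here, compound 3 `CC1=CC[C@H](C(C)(C)NC(=S)N/N=C/c2cccc(Cl)c2)CC1` gives 1400 nM, and the change an at least 71-fold lower number from compound 2 to compound 3 (1.85 log units; beyond the scatter) is the only measured step in the set. Compound 4 `CC1=CC[C@H](C(C)(C)NC(=S)N/N=C/c2ccc(Cl)cc2)CC1` differs from compound 2 by chloro in place of hydroxy on an aromatic carbon. The step from compound 2 to compound 3 bears on this: it too puts a chloro in place of a hydroxy, though as 3-chlorophenyl rather than 4-chlorophenyl. A large drop in this assay is therefore expected, with compound 4 probably off the limit. Compound 4 is estimated at 3000 nM, range 800 nM to 25000 nM, an expected step of an at least 33-fold lower number from compound 2 to compound 4 (1.52 log units; beyond the scatter).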

Compound 4, concentration for 50% growth inhibition: 7800 nM
Beside the measured number, compound 4's estimate is 2.6-fold (0.41 log units) below it, and the stated range covers the measured number.
By their numbers in this assay, from the lowest: compound 3; then compound 4; then compound 1. At a limit, above all of these: compound 2.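

The drop in this assay with chloro in place of hydroxy is not confined to one ring position: 4-chlorophenyl also gives an at least 12-fold lower number from compound 2 to compound 4 (1.10 log units; beyond the scatter). The position of the chloro still matters, with a 5.6-fold higher number from compound 3 to compound 4 (0.75 log units; beyond the scatter), so 3-chlorophenyl keeps the lower number of the pair. The value for compound 2 is a limit of the assay and not a number, so the true size of both chloro steps stays unknown: the limit of > 100000 nM in this assay, at which 1 of the 4 values shown sits.

Going by these compounds, it remains open whether this drop is specific to chloro or would also appear with a methyl or an amine on the same aromatic carbon.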